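The source may report more compounds than this note shows. Statements on the series, on what has been measured and on what is new or still open speak of the compounds shown alone.

Measured compounds:
- compound 1, `COc1ccccc1-c1cccc(S(=O)(=O)N2CCC(N3CCC(C)CC3)CC2)c1`: 21 nM
- compound 2, `CCCOc1ccc(S(=O)(=O)N2CCC(N3CCC(C)CC3)CC2)cc1`: 452 nM

Both were tested in a functional assay on DLD-1 cells (Homo sapiens) for antiproliferative activity, read by CellTiter-Glo, with a stated time of 72 h; on this read-out lower numbers stand for stronger inhibition and higher numbers for weaker inhibition. Compound 1 gives 21 nM there, the lower of the two numbers, while compound 2 gives 452 nM, a gap well beyond the usual scatter, so compound 1 is the stronger inhibitor of the pair.

The next compound keeps the core of compound 1 and alters only the aryl group on it. In compound 3, `Cc1cc(C)cc(-c2cccc(S(=O)(=O)N3CCC(N4CCC(C)CC4)CC3)c2)c1`, the change is 3,5-dimethylphenyl in place of 2-methoxyphenyl on an aromatic carbon; the new group sits meta to a large group, exactly where the old one stood. Nothing measured here shows how such a swap moves the read-out, so the expectation rests only on compound 1. A modest step, no larger than the scatter or slightly weaker, is expected, giving a 1.9-fold higher number from compound 1 to compound 3 (0.28 log units; within the scatter). Compound 3 is therefore estimated at 40 nM, with a range from 10 nM to 160 nM.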

Compound 3, half-maximal inhibitory concentration: 41 nM
Beside the measured number, compound 3's estimate is 1.0-fold (0.01 log units) below it, within the range that was stated.
By their numbers in this assay, from the lowest: compounds 1 and 3 (each within the scatter of the next); then compound 2.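

In this assay, placing 3,5-dimethylphenyl where 2-methoxyphenyl stood gives a 2.0-fold higher number from compound 1 to compound 3 (0.29 log units; within the scatter) so this read-out does not separate the two compounds. This shows that the position can carry two different substituted phenyl rings: the entering group has no hydrogen-bond acceptor, the leaving group has one, and the two numbers still lie within the scatter of each other. Nothing available explains why the two groups read alike.

Still open, going by these compounds, is how this position responds to a phenyl ring bearing an amine or a carboxylic acid, or to a saturated ring such as cyclohexyl in place of the aryl group. Also open, on these data alone, is whether plain phenyl, or a phenyl ring with a single methyl group, would read like compound 3.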